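From ethyl to methyl at the assay limit

The source may report more compounds than this note shows. Statements on the series, on what has been measured and on what is new or still open speak of the compounds shown alone.

Measured in a functional assay on HL-60 cells (Homo sapiens) for antiproliferative activity, with a stated time of 72 h; on this read-out higher numbers stand for weaker inhibition of growth and lower numbers for stronger inhibition of growth:
- Compound 1 `C=C(CC)C(=O)c1ccc(OCC(=O)O)cc1Br`: > 60000 nM (a limit)
- Compound 2 `C=C(CC)C(=O)c1ccc(OCC(=O)O)cc1Cl`: > 60000 nM (a limit)

Compound 2 gives only a limit, > 60000 nM, and not a number. The same holds across the pair so far, as the limit of > 60000 nM in this assay, at which 2 of the 2 values shown sit, shows. Compound 3 `C=C(C)C(=O)c1ccc(OCC(=O)O)cc1Cl` differs from compound 2 by one small change: hydrogen in place of methyl on a saturated chain carbon bound to a double-bonded chain carbon. In words, this is hydrogen in place of methyl on a saturated chain carbon bound to a double-bonded chain carbon, and the same difference reads ethyl to methyl. Going by the values given here, the only measured step is a step that the two limits leave unreadable from compound 1 to compound 2, with chloro in place of bromo on an aromatic carbon. It concerns another place and offers no size to carry over, so no shift beyond the scatter is expected in this assay. The expected size is a number no higher from compound 2 to compound 3 (the limit leaves the size open). Compound 3 is estimated at 60000 nM, within an expected range of 20000 nM to 100000 nM.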

Compound 3, concentration for 50% growth inhibition: > 60000 nM
Compound 3: only a limit was reported (the forecaster's own chance of this, stated with the estimate: 80%); the middle value lies on the limit itself.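

In this assay compound 3 gives > 60000 nM, a limit and not a number. Compound 2 also gives only a limit, so the step from ethyl to methyl between compound 2 and compound 3 cannot be read. The compounds shown leave open how strongly each inhibits growth, and whether either change alters it: the limit of > 60000 nM in this assay, at which 3 of the 3 values shown sit.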